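From propylsulfanyl to benzylsulfanyl on a shared core

The source may hold more compounds than are shown below. What is called first, only, known or untested is meant among the compounds shown, and "the series" means these compounds.

Compound 1, `C#CCSc1nc(N/N=C/c2cc(OC)c(OC)c(OC)c2)c2nnn(Cc3ccccc3)c2n1`: 6540 nM
Compound 2, `CCCSc1nc(N/N=C/c2cc(OC)c(OC)c(OC)c2)c2nnn(Cc3ccccc3)c2n1`: 4060 nM

In a functional assay on ECa-109 cells (Homo sapiens) for antiproliferative activity, read by MTT assay, with a stated time of 72 h (a higher number here means a weaker inhibitor, a lower number a stronger inhibitor), compound 2 and compound 1 sit within the scatter of each other, the step of a 1.6-fold lower number from compound 1 to compound 2 (0.21 log units; within the scatter) being the only one measured. Compound 3, `COc1cc(/C=N/Nc2nc(SCc3ccccc3)nc3c2nnn3Cc2ccccc2)cc(OC)c1OC`, differs from compound 2 by phenyl in place of ethyl on a saturated chain carbon bound to a sulfur, which read one bond further out is propylsulfanyl to benzylsulfanyl. Among the compounds with values here, the step of a 1.6-fold lower number from compound 1 to compound 2 (0.21 log units; within the scatter) touches the same carbon but only swaps two small chains; no measured step brings a ring into this place, so the change is estimated to stay modest, a 1.6-fold lower number from compound 2 to compound 3 (0.21 log units; within the scatter). Compound 3 is therefore expected to give 2500 nM, with a range from 800 nM to 8000 nM.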

Compound 3, half-maximal inhibitory concentration: 4400 nM
The estimate for compound 3 lay 1.8-fold (0.25 log units) below the measured number, within the range that was stated.
By their numbers in this assay, from the lowest: compounds 2, 3 and 1 (each within the scatter of the next).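

In this assay, phenyl on the saturated chain carbon bound to a sulfur gives a number within the scatter of both small chains (a 1.1-fold higher number from compound 2 to compound 3 (0.03 log units; within the scatter); a 1.5-fold lower number from compound 1 to compound 3 (0.17 log units; within the scatter)). This is the first ring shown at this place, and neither step lies beyond the scatter, so propylsulfanyl and benzylsulfanyl cannot be told apart here. The compounds shown leave open whether an amine or a carboxylic acid on this chain would give a step beyond the scatter. No supporting evidence bears on this result.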